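A Nitro Group on the Phenyl of Compound 2

A few compounds are considered here, and "the series" means these few. Any claim that something is new, unique, unknown or untested is made for them only; others in the source may bear on it.

Compound 1 `CCOC(=O)C1=Cc2ccccc2OC1(OCc1cn(CC(=O)Nc2ccc(OC)cc2)nn1)C(F)(F)F` gives 28100 nM in a functional assay on MCF7 cells (Homo sapiens) for inhibition, read by MTT assay, with a stated time of 24 h; a lower number here means a stronger inhibitor, a higher number a weaker inhibitor. Compound 2 `CCOC(=O)C1=Cc2ccccc2OC1(OCc1cn(-c2ccccc2)nn1)C(F)(F)F` reaches only the limit > 150000 nM in this assay, so it is a limit and not a number. Compound 3 `O=C(O)C1=Cc2ccccc2OC1(OCc1cc(-c2ccc(F)cc2F)no1)C(F)(F)F` likewise sits at the limit > 150000 nM.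

Within the data shown here, the one measured step between close neighbours is an at least 5.3-fold higher number from compound 1 to compound 2 (0.72 log units; beyond the scatter), and it leaves compound 2 standing at the limit of > 150000 nM in this assay, at which 2 of the 3 values shown sit. Compound 4 `CCOC(=O)C1=Cc2ccccc2OC1(OCc1cn(-c2ccc([N+](=O)[O-])cc2)nn1)C(F)(F)F` differs from compound 2 by nitro in place of hydrogen on an aromatic carbon. Among the measured compounds shown here, no measured step here changes a substituent on that ring, so the available steps give no direction for this assay. Compound 4 is therefore expected to stay near the limit, with an expected step of an at least 1.2-fold lower number from compound 2 to compound 4 (0.09 log units; that floor lies within the scatter). The estimate for compound 4 is 120000 nM, between 30000 nM and 300000 nM.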

Compound 4, half-maximal inhibitory concentration: > 150000 nM
Compound 4 gave a limit, no number (the forecaster's own chance of this, stated with the estimate: 60%); middle value at least 1.2-fold (0.09 log units) from the limit.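

Putting nitro on the phenyl of compound 2 does not produce a readable number in this assay: compound 4 also stops at a limit, and the step between these two limits cannot be read. Replacing ((4-methoxyphenyl)carbamoyl)methyl with 4-nitrophenyl gives an at least 5.3-fold higher number from compound 1 to compound 4 (0.72 log units; beyond the scatter), so a substituted phenyl falls short of compound 1 just as plain phenyl does. The limit now covers most of the set: the limit of > 150000 nM in this assay, at which 3 of the 4 values shown sit.

From the compounds shown here alone, whether an amine or a hydroxyl group on that phenyl would give a readable number remains open. Also open, going by these compounds, is which part of the ((4-methoxyphenyl)carbamoyl)methyl group matters for the measurable result of compound 1.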